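Chloro for methyl on the amide-bearing ring: expected solubility

The source may hold more compounds than are shown below. What is called first, only, known or untested is meant among the compounds shown, and "the series" means these compounds.

Measured so far in a physicochemical assay for solubility, read by HPLC, in phosphate buffer, measured as thermodynamic solubility, with a stated time of 24 h, at pH 6.8; on this read-out higher numbers stand for higher solubility and lower numbers for lower solubility:
Compound 1 `CCNC(=O)c1ccc(-c2cc3nnn(C4CCN(c5ncc(CC)cn5)CC4)c3cn2)c(C)c1` gives < 90 nM, which is a limit of the assay rather than a number.
Compound 2 `CCNC(=O)c1ccc(-c2cc3nnn(C4CCN(c5ncc(CC)cn5)CC4)c3cn2)c(Cl)c1` gives 240 nM.
Compound 3 `CCNC(=O)c1ccc(-c2cc3nnn(C4CCN(c5ncc(CC)cn5)CC4)c3cn2)cc1C` gives 1790 nM.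

Compounds 1 and 2 differ in one group only: chloro in place of methyl on an aromatic carbon. On these data alone, this swap gave an at least 2.6-fold higher number from compound 1 to compound 2 (0.42 log units; beyond the scatter), though its full size is unknown since compound 1 sits at the limit of < 90 nM in this assay, at which 1 of the 3 values shown sits. Compound 3 is built from the same atoms as compound 1, joined differently; the difference between the two cores is not broken down here. Among the numbers in this assay, compound 3 stands highest, with compound 2 nearest.

Compound 4 `CCNC(=O)c1ccc(-c2cc3nnn(C4CCN(c5ncc(CC)cn5)CC4)c3cn2)cc1Cl` is not yet measured. It differs from compound 3 by chloro in place of methyl on an aromatic carbon, the same kind of change as between compounds 1 and 2, but not the same: in compound 2 the chloro is ortho to a large group and meta to an ethylcarbamoyl group, whereas in compound 4 it is ortho to an ethylcarbamoyl group and meta to a large group.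

In this assay compound 4 is expected to show a 1.7-fold higher number from compound 3 to compound 4 (0.22 log units; within the scatter), a modest rise beside the earlier one, resting on an at least 2.6-fold higher number from compound 1 to compound 2 (0.42 log units; beyond the scatter). Compound 4 is therefore estimated at 3000 nM, likely between 900 nM and 9000 nM.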

Compound 4, solubility: < 160 nM
Compound 4: a limit, no number (the forecaster's own chance of this, stated with the estimate: 5%); at least 18-fold (1.27 log units) between middle value and limit.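

In this assay, chloro in place of methyl gave an at least 2.6-fold higher number from compound 1 to compound 2 (0.42 log units; beyond the scatter), whereas with the chloro ortho to an ethylcarbamoyl group it gave an at least 11-fold lower number from compound 3 to compound 4 (1.04 log units; beyond the scatter), so the direction of this change did not carry from the core of compound 1 to the core of compound 3. These two pairs show that one swap can go opposite ways within this series, but they give no general rule and do not show why the two results differ. Compound 4 gives a limit of the assay rather than a number, so the new step gives only a minimum size: the limit of < 160 nM in this assay, at which 1 of the 4 values shown sits.

The compounds shown leave open how a fluoro or a methoxy group in place of the chloro would read in this assay on each core. They also leave open whether a longer chain in place of the ethyl of the ethylcarbamoyl group would keep the same contrast between the two cores.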